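The source may report more compounds than this note shows. Statements on the series, on what has been measured and on what is new or still open speak of the compounds shown alone.

Working notes on the series. Compound 1 `CCc1nc2ccccc2n1CCCCOc1ccc(C)cc1` is characterised in an ADME assay on Vero cells (Chlorocebus sabaeus) for cytotoxicity, read by luminescence, with a stated time of 2 days (on this read-out higher numbers stand for lower toxicity in this test and lower numbers for higher toxicity in this test), and gives 14 uM there. Compound 2 `CCc1nc2ccc(C)cc2n1CCCSc1ccc(C)cc1`, which shares the core, gives 12 uM in this assay; the two numbers lie within the scatter of each other, so compound 1 and compound 2 cannot be told apart on this read-out, and compound 1 is simply one of two closely placed points.

Compound 3 `CCc1nc2ccccc2n1CCCCOC` is the next member and has not yet been run in this assay. Relative to compound 1 it carries the change (methyl in place of 4-methylphenyl on an oxygen on a saturated carbon), so the 4-methylphenyl on the oxygen is replaced by a single methyl carbon while the rest of the structure, including the ethyl on the core and the four-carbon linker, is untouched.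

Among the compounds with values here, no comparable pair of measured compounds is at hand to size this step. The expectation is a small shift in this assay, towards a higher half-maximal toxic concentration for compound 3, but possibly not beyond the scatter; the step from compound 1 to compound 3 is estimated as a 1.8-fold higher number from compound 1 to compound 3 (0.25 log units; within the scatter). On that basis compound 3 is expected to give about 25 uM in this assay, within a range from 10 uM to 70 uM.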

Compound 3, half-maximal toxic concentration: > 50 uM
Compound 3: no number, only a limit (the forecaster's own chance of this, stated with the estimate: 20%); at least 2.0-fold (0.30 log units) between middle value and limit.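

Replacing the 4-methylphenyl by methyl, on an oxygen on a saturated carbon, gives in this assay an at least 3.5-fold higher number from compound 1 to compound 3 (0.55 log units; beyond the scatter). Within the data shown here, this is the first step that can be read at this position, and it shows that the group on this oxygen can move the read-out beyond the scatter, towards lower toxicity in this test. The value of compound 3 is a limit and not a number, so the step has a lower bound but no measured size: the limit of > 50 uM in this assay, at which 1 of the 3 values shown sits.

The compounds shown leave open whether the shift follows the six-membered aromatic ring itself or simply the number of heavy atoms in the group on the oxygen, as the change from compound 1 to compound 3 alters both at once. A phenyl without the methyl, a cyclohexyl or a longer alkyl chain on the same oxygen would separate these two readings, and an amine or a carboxylic acid at the end of the chain would show how far the read-out responds to groups of another kind.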